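This account rests on a few compounds, and the source may have more. Where it says the series, first, only, none or still open, it means among the compounds named here.

Measured compounds:
- compound 1 `O=C(O)c1ccccc1-c1ccc(CCc2ncc(CC3CCC3)[nH]2)cc1` – 7.1 nM
- compound 2 `O=C(O)c1ccccc1-c1ccc(CCc2ncc(Cc3ccccc3F)[nH]2)cc1` – 9.5 nM
- compound 3 `N#Cc1ccc(Cc2cnc(CCc3ccc(-c4ccccc4C(=O)O)cc3)[nH]2)cc1` – 723 nM

All three share one core and differ only in the group on a saturated chain carbon bound to an aromatic carbon. In an in vitro functional assay on cells for agonist activity at Bombesin receptor subtype-3 (Mus musculus), read by luminescence and calcium flux (on this read-out higher numbers stand for an effect only at larger amounts of compound and lower numbers for an effect already at smaller amounts), compound 1 gives 7.1 nM and compound 2 gives 9.5 nM; the step of a 1.3-fold higher number from compound 1 to compound 2 (0.13 log units; within the scatter) lies within the scatter. Compound 3 stands apart: it gives the highest number of the three, with a 100-fold higher number from compound 1 to compound 3 (2.01 log units; beyond the scatter) and a 76-fold higher number from compound 2 to compound 3 (1.88 log units; beyond the scatter), both large.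

Compound 4 `O=C(O)c1ccccc1-c1ccc(CCc2ncc(Cc3ccc(Cl)cc3)[nH]2)cc1` is not yet measured. Relative to compound 3 the change is chloro in place of cyano on an aromatic carbon. The cyano group leaves and a chloro group enters on the same aromatic carbon, para to a large group.

For the measured compounds named here, no measured step exchanges these two groups directly. Going by the values given here, the steps that bear on it are a 100-fold higher number from compound 1 to compound 3 (2.01 log units; beyond the scatter) and a 76-fold higher number from compound 2 to compound 3 (1.88 log units; beyond the scatter), which show that the 4-cyanophenyl group carries a large penalty compared with cyclobutyl or 2-fluorophenyl. Whether the penalty belongs to the cyano group itself or to the whole 4-substituted phenyl cannot be separated from these data. The expectation is therefore a moderate move toward lower numbers, a 4.8-fold lower number from compound 3 to compound 4 (0.68 log units; beyond the scatter), but not a full return to compound 1 or compound 2. Compound 4 is estimated at 150 nM, with a range from 30 nM to 700 nM.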

Compound 4, half-maximal effective concentration: 102 nM
Estimate against measurement, compound 4: 1.5-fold (0.17 log units) above, and the stated range covers the measured number.
By their numbers in this assay, from the lowest: compounds 1 and 2 (each within the scatter of the next); then compound 4; then compound 3.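

Putting chloro in place of cyano on the same aromatic carbon, para to a large group, gives a 7.1-fold lower number from compound 3 to compound 4 (0.85 log units; beyond the scatter) in this assay. This shows that the large penalty seen with the 4-cyanophenyl group is not shared in full by every 4-substituted phenyl group, so the substituent on this carbon matters in its own right. Even so, much of the gap remains with 4-chlorophenyl, with an 11-fold higher number from compound 2 to compound 4 (1.03 log units; beyond the scatter) and a 14-fold higher number from compound 1 to compound 4 (1.16 log units; beyond the scatter), both large, so swapping cyano for chloro recovers only part of the difference from the 2-fluorophenyl and cyclobutyl groups.

No measurement here explains why these groups differ in this way. On these data alone, it also stays open whether the remaining gap belongs to the chloro group or to having any substituent on that carbon, since 2-fluorophenyl and 4-chlorophenyl differ in both the halogen and its place on the ring; an unsubstituted phenyl group, or a methoxy group on that same aromatic carbon, would be the kind of comparison needed to separate the two.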